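The compounds below may be only part of what the source reports. "The series", "measured", "known", "first", "only" and "open" are said of these compounds alone.

Measured so far in a functional assay on the whole organism for inhibition, with Rattus norvegicus as the target; a higher number here means that more compound is needed for the effect, a lower number that less compound is needed:

- compound 1, `CC1CC/C(=N\Nc2ccc(F)cc2)c2ncc(C(=O)O)c(=O)n21`: > 1000 umol/kg
- compound 2, `CC1CC/C(=N\Nc2ccccc2Cl)c2ncc(C(=O)O)c(=O)n21`: > 1000 umol/kg
- compound 3, `CC1CC/C(=N\Nc2ccc(O)cc2)c2ncc(C(=O)O)c(=O)n21`: > 100 umol/kg

Each of these readings is a limit of the assay, not a number. Compound 1 sits at a limit, > 1000 umol/kg. Compound 2 likewise sits at a limit, > 1000 umol/kg. Among the compounds with values here, compound 3 stands at a limit of > 100 umol/kg, and this is the single reading at the limit of > 100 umol/kg in this assay, at which 1 of the 3 values shown sits. The other two readings sit at the limit of > 1000 umol/kg in this assay, at which 2 of the 3 values shown sit. All three values being limits, the steps a step that the two limits leave unreadable from compound 1 to compound 2, a step that the two limits leave unreadable from compound 1 to compound 3 and a step that the two limits leave unreadable from compound 2 to compound 3 have no readable size.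

Compound 4, `CC1CC/C(=N\Nc2ccc(C(F)(F)F)cc2)c2ncc(C(=O)O)c(=O)n21`, is not yet measured in this assay. It differs from compound 3 by trifluoromethyl in place of hydroxy on an aromatic carbon. Within the data shown here, the steps that bear on this change are the three among compounds 1, 2 and 3, and none of them yields a readable size, so they give no direction for the new step. With every reading in the series a limit, compound 4 is expected to stay at a limit as well, and the step that the limit leaves unreadable from compound 3 to compound 4 is estimated as no more than the limits allow. Compound 4 is expected near 1500 umol/kg, within 300 umol/kg to 6000 umol/kg, most probably reported again as a limit.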

Compound 4, dose for 50% inhibition: > 1000 umol/kg
Compound 4: no number, only a limit; the forecaster's own chance of this, stated with the estimate: 85%; the middle value lies beyond the limit too.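

Within the data shown here, no step to compound 4 can be read in this assay: compounds 1, 3 and 4 all carry limits only, so neither replacement by trifluoromethyl has a readable size. The compounds shown leave open whether any of them has a measurable inhibitory dose, and whether the substituent on the phenyl ring changes it.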